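The source may report more compounds than this note shows. Statements on the series, on what has been measured and on what is new or still open speak of the compounds shown alone.

Measured so far in a functional assay on MGC-803 cells (Homo sapiens) for inhibition; on this read-out higher numbers stand for weaker inhibition and lower numbers for stronger inhibition:
Compound 1 `CCN(C(=O)CC(CC(=O)NCCN1CCCC1)c1ccc(Cl)cc1)C1Cc2ccccc2C1`: 55500 nM
Compound 2 `CCN(CC)CCNC(=O)CC(CC(=O)N(CC)C1Cc2ccccc2C1)c1ccc(Cl)cc1`: 44900 nM

For the measured compounds named here, these two values lie close together, with a 1.2-fold lower number from compound 1 to compound 2 (0.09 log units; within the scatter), so compound 1 cannot be ranked against its only measured neighbour.

The next compound is compound 3 `CCN(C(=O)CC(CC(=O)NCCN1CCCC1)c1ccccc1)C1Cc2ccccc2C1`, which differs from compound 1 by a single change: hydrogen in place of chloro on an aromatic carbon. Put simply, hydrogen stands in place of chloro on an aromatic carbon, turning 4-chlorophenyl into phenyl.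

Going by the values given here, the one measured step bears on this only indirectly. It exchanges pyrrolidin-1-yl for diethylamino on the chain and leaves the chloro untouched. Among the compounds with values here, no measured pair shows what losing the chloro does in this assay, so the data give no direction. The best starting point is therefore compound 1 at 55500 nM, and no step beyond the scatter is expected, although this expectation is loosely held. The estimated change is a 1.2-fold higher number from compound 1 to compound 3 (0.07 log units; within the scatter). Compound 3 is expected at about 65000 nM, with an estimated range from 28000 nM to 150000 nM.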

Compound 3, half-maximal inhibitory concentration: > 100000 nM
Compound 3: only a limit was reported; the forecaster's own chance of this, stated with the estimate: 15%; at least 1.5-fold (0.18 log units) between middle value and limit.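

Compound 3 gives the first measured view of what the chloro on the aromatic ring contributes in this assay, and the step reads an at least 1.8-fold higher number from compound 1 to compound 3 (0.25 log units; that floor lies within the scatter). For compound 3, > 100000 nM is a limit of the assay and not a number. With hydrogen in place of chloro, the change from 4-chlorophenyl to phenyl therefore points towards weaker inhibition, but the smallest step it allows stays within the scatter, so it does not yet show that the chloro matters, and the true size of the step remains hidden: the limit of > 100000 nM in this assay, at which 1 of the 3 values shown sits.

The compounds shown leave open whether another group on that aromatic carbon, such as fluoro, bromo, methyl or methoxy, would give a lower or a higher number than chloro does. They also leave open whether the same change would read alike with diethylamino in place of pyrrolidin-1-yl on the chain, and a phenyl partner of compound 2 would answer that.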